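The source may hold more compounds than are shown below. What is called first, only, known or untested is meant among the compounds shown, and "the series" means these compounds.

Compound 1, `CCNc1cc(-c2ccc(NC(=O)Nc3ccc(C)cc3)cc2C)ccn1`: 22000 nM
Compound 2, `CCNc1cc(-c2ccc(NC(=O)Nc3cccc(Cl)c3)cc2C)ccn1`: 16600 nM
Compound 3, `CCNc1cc(-c2ccc(NC(=O)Nc3ccc(C)cc3)cc2C(F)(F)F)ccn1`: 27100 nM

These values come from a functional assay on BT-483 cells (Homo sapiens) for cytotoxicity, read by MTT assay, with a stated time of 24 h; a higher number here means a weaker inhibitor, a lower number a stronger inhibitor. Compound 3 lies within the scatter of both compound 1 and compound 2, so the three cannot be told apart. Compound 4, `CCNc1cc(-c2ccc(NC(=O)Nc3cccc(Cl)c3)cc2C(F)(F)F)ccn1`, carries 3-chlorophenyl in place of 4-methylphenyl on an amide-type nitrogen of compound 3: 3-chlorophenyl in place of 4-methylphenyl on an amide-type nitrogen. The same exchange has been measured once, as a 1.3-fold lower number from compound 1 to compound 2 (0.12 log units; within the scatter). Trifluoromethyl in place of methyl, the other difference among these compounds, gave a 1.2-fold higher number from compound 1 to compound 3 (0.09 log units; within the scatter). With both steps this small, nothing beyond the scatter is expected from the exchange. The expected size is an estimated 1.3-fold lower number from compound 3 to compound 4 (0.12 log units; within the scatter). Compound 4 is expected at about 20500 nM, within an estimated range of 12000 nM to 35000 nM.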

Compound 4, half-maximal inhibitory concentration: 13300 nM
Compound 4: the middle estimate sits 1.5-fold (0.19 log units) above what was measured; measured number inside the range.
By their numbers in this assay, from the lowest: compounds 4, 2, 1 and 3 (each within the scatter of the next, the first and the last beyond it).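

In this assay, within the data shown here, 3-chlorophenyl in place of 4-methylphenyl on the amide-type nitrogen gives a 2.0-fold lower number from compound 3 to compound 4 (0.31 log units; beyond the scatter), the first step in this set to pass the scatter, though only modestly. Read on two cores, the exchange points the same way, and the two readings do not differ beyond the scatter: the same change on two cores in this assay, a 1.3-fold lower number (0.12 log units; within the scatter) from compound 1 to compound 2 and a 2.0-fold lower number (0.31 log units; beyond the scatter) from compound 3 to compound 4, 1.5-fold (0.19 log units) apart, within the scatter of two such steps Trifluoromethyl in place of methyl still shows no clear change, with a 1.2-fold lower number from compound 2 to compound 4 (0.10 log units; within the scatter).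

The compounds shown cannot separate the effect of chlorine from that of its place on the ring, which 4-chlorophenyl could address. On these data alone, a phenyl carrying an amine or a carboxylic acid at this nitrogen also remains open.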